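Ring Swaps on One Aromatic Carbon of a Shared Core

The compounds below may be only part of what the source reports. "The series", "measured", "known", "first", "only" and "open" are said of these compounds alone.

Measured compounds in this assay:
compound 1 `CC(C(=O)NCc1ccc(C(F)(F)F)cc1N1CCCC1)c1ccc(NS(C)(=O)=O)c(F)c1` gives 2.3 nM
compound 2 `CC(C(=O)NCc1ccc(C(F)(F)F)cc1N1CCCCCCC1)c1ccc(NS(C)(=O)=O)c(F)c1` gives 2.8 nM
compound 3 `CC(C(=O)NCc1ccc(C(F)(F)F)cc1N1CCC(C)(C)CC1)c1ccc(NS(C)(=O)=O)c(F)c1` gives 1.3 nM

In an assay on CHO cells for antagonist activity at transient receptor potential cation channel subfamily V member 1 (Homo sapiens), read by FLIPR (a higher number here means a weaker inhibitor, a lower number a stronger inhibitor), compound 3 gives 1.3 nM, the lowest of the three numbers. Its nearest neighbour is compound 1, with a 1.8-fold lower number from compound 1 to compound 3 (0.25 log units; within the scatter), a difference that stays within the scatter; the furthest is compound 2, with a 2.2-fold lower number from compound 2 to compound 3 (0.33 log units; beyond the scatter), a modest step beyond the scatter. Compound 4 `CC(C(=O)NCc1ccc(C(F)(F)F)cc1N1CCN(C2CCCCC2)CC1)c1ccc(NS(C)(=O)=O)c(F)c1` is the next member of the series. It differs from compound 3 in one place: 4-cyclohexylpiperazin-1-yl in place of 4,4-dimethylpiperidin-1-yl on an aromatic carbon.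

All three measured steps concern a change of the saturated ring on this same aromatic carbon. Going from the five-membered to the eight-membered ring gave a 1.2-fold higher number from compound 1 to compound 2 (0.09 log units; within the scatter); the two other swaps gave a 1.8-fold lower number from compound 1 to compound 3 (0.25 log units; within the scatter) and a 2.2-fold lower number from compound 2 to compound 3 (0.33 log units; beyond the scatter). For the measured compounds named here, none of these moved the number by more than a modest amount, and no measured compound carries a second ring or a second nitrogen in this position, so there is no direct precedent for that part of the change. The account therefore expects a small step, a 2.3-fold higher number from compound 3 to compound 4 (0.36 log units; beyond the scatter), in either direction but most likely a slightly higher number. For compound 4 the estimated value is 3 nM, with a range from 0.8 nM to 12 nM.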

Compound 4, inhibition constant: 13.8 nM
The estimate for compound 4 lay 4.6-fold (0.66 log units) below the measured number; the measured number lies above the stated range.
By their numbers in this assay, from the lowest: compounds 3, 1 and 2 (each within the scatter of the next, the first and the last beyond it); then compound 4.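

In this assay, for the compounds shown here, the change from 4,4-dimethylpiperidin-1-yl to 4-cyclohexylpiperazin-1-yl (an 11-fold higher number from compound 3 to compound 4 (1.03 log units; beyond the scatter)) is the first large step at this aromatic carbon, where the earlier ring swaps had stayed within the scatter or only just beyond it. The steps from the other two single-ring compounds point the same way (a 6.0-fold higher number from compound 1 to compound 4 (0.78 log units; beyond the scatter); a 4.9-fold higher number from compound 2 to compound 4 (0.69 log units; beyond the scatter)), so 4-cyclohexylpiperazin-1-yl stands apart from all three earlier groups at this position. Nothing available accounts for this higher number.

The compounds shown carry the second nitrogen and the cyclohexyl ring together, so they leave open which of the two goes with the higher number. A 4-methylpiperazin-1-yl or a 4-cyclohexylpiperidin-1-yl group on this carbon would separate them.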